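Chloro scan on two isomeric cores of an alkyne series

The compounds below may be only part of what the source reports. "The series", "measured", "known", "first", "only" and "open" are said of these compounds alone.

Compound 1 `Fc1cccc(F)c1C#Cc1cncc2ccccc12` in a functional assay on LS174T cells (Homo sapiens) for inhibition, with a stated time of 4 days, tested at 10 uM (a lower number here means a weaker effect, a higher number a stronger effect of the compound at the concentration tested), gives 87.9%. Compound 2 `Fc1cccc(F)c1C#Cc1cnc(Cl)c2ccccc12` gives 94% in this assay; the step of a number 6.1 percentage points higher from compound 1 to compound 2 (within the scatter) comes from chloro in place of hydrogen on an aromatic carbon. Compound 3 `Fc1cccc(F)c1C#Cc1ccnc2ccccc12` holds the same atoms as compound 1 joined differently, and how the two cores differ is not broken down here; in this assay compound 3 gives 59%, the lowest of the three numbers and beyond the scatter from both compound 1 and compound 2.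

Compound 4 `Fc1cccc(F)c1C#Cc1ccnc2cc(Cl)ccc12` has not yet been measured in this assay. Relative to compound 3 it carries chloro in place of hydrogen on an aromatic carbon, the same kind of change as from compound 1 to compound 2, though the place differs: in compound 2 the chloro sits on a six-membered aromatic ring with one nitrogen, next to the ring nitrogen, ortho to a fused ring, meta to a fused ring and para to a large group, whereas in compound 4 it sits on a six-membered aromatic ring of carbon only, meta to a fused ring and para to a fused ring. The expected step of a number 6 percentage points higher from compound 3 to compound 4 (within the scatter) is set beside a number 6.1 percentage points higher from compound 1 to compound 2 (within the scatter), which stayed within the scatter, and rests on that single precedent only. For compound 4 the estimate is 65% in this assay, expected to fall between 45% and 82%.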

Compound 4, a percentage reported as inhibition, at one concentration (the size of the read-out at that concentration, not a potency): 74.3%
Estimate against measurement, compound 4: 9.3 percentage points below; the range from low to high includes it.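

In this assay, chloro in place of hydrogen on an aromatic carbon of the core of compound 3 gives a number 15.3 percentage points higher from compound 3 to compound 4 (beyond the scatter). Set beside the earlier step on the core of compound 1, this does not mark the two cores as responding differently: the same change on two cores in this assay, a number 6.1 percentage points higher (within the scatter) from compound 1 to compound 2 and a number 15.3 percentage points higher (beyond the scatter) from compound 3 to compound 4, 9.2 percentage points apart, within the scatter of two such steps This rests on only two pairs, in which the chloro also sits in different places, so the effect of the core cannot be separated from that of the place, and a read-out at one concentration says nothing about potency.

Still open, on these data alone, is whether a chloro on the six-membered aromatic ring of carbon only gives a comparable step on the core of compound 1, which would compare the two cores at a matching place. Also open, as far as these compounds go, is whether the step is specific to chloro, or whether a fluoro, methyl, methoxy or amine group at the place it occupies in compound 4 would give a similar read-out.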